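The source may report more compounds than this note shows. Statements on the series, on what has been measured and on what is new or still open speak of the compounds shown alone.

Measured so far in a functional assay on the whole organism (strain Swiss albino) for inhibition, with Mus musculus as the target, in the writhing test, with stated times of 60 min and 15 min, at a dose of 100 mg/kg by the oral route; a higher number here means more inhibition at the dose given (going by the name of the read-out), a lower number less inhibition:
compound 1 `COc1cc2c(cc1OC)C(CC(=O)O)CC2`: 44%
compound 2 `CNC(=O)CC1CCc2cc(OC)c(OC)cc21`: 21.2%
compound 3 `COc1cc2c(cc1OC)C(CC(=O)NC(C)(C)C)CC2`: 41.8%

Compound 2 stands lowest of the three numbers. Nearest is compound 3: a number 20.6 percentage points higher from compound 2 to compound 3 (beyond the scatter). Furthest is compound 1, on the far side of the same gap: a number 22.8 percentage points lower from compound 1 to compound 2 (beyond the scatter).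

Compound 4 `COc1cc2c(cc1OC)C(CC(=O)NC1CCCC1)CC2` is not yet measured. It differs from compound 2 in one place: cyclopentyl in place of methyl on an amide-type nitrogen. One measured step sits on the same amide-type nitrogen, a number 20.6 percentage points higher from compound 2 to compound 3 (beyond the scatter), where methyl also gave way to a group built of more carbon atoms, and the result was beyond the scatter. On that single precedent an upward step of comparable size is expected in this assay: a number 18.8 percentage points higher from compound 2 to compound 4 (beyond the scatter). Compound 4 is therefore estimated at 40%, with a range from 25% to 55%.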

Compound 4, a percentage reported as inhibition, in the whole organism at one dose (the size of the read-out at that dose, not a potency): 37%
The estimate for compound 4 lay 3 percentage points above the measured number; the measured number falls inside the stated range.
By their numbers in this assay, from the lowest: compound 2; then compounds 4, 3 and 1 (each within the scatter of the next).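

On the amide-type nitrogen, cyclopentyl repeats the rise over methyl in this assay (a number 15.8 percentage points higher from compound 2 to compound 4 (beyond the scatter)), so that rise is no longer tied to tert-butyl alone. Cyclopentyl and tert-butyl cannot be told apart here (a number 4.8 percentage points lower from compound 3 to compound 4 (within the scatter)), and the cyclopentylamino amide cannot be told apart from the hydroxy compound (a number 7 percentage points lower from compound 1 to compound 4 (within the scatter)). No measurement bears on the reason for the difference from methyl. Open, going by these compounds, is where ethyl or isopropyl on this nitrogen would fall between methyl and the larger groups. Also open, on these data alone, is how phenyl or an unsubstituted amide would compare.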